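Trichloro to dibromochloro swap on the sulfonamide aryl

The compounds below may be only part of what the source reports. "The series", "measured", "known", "first", "only" and "open" are said of these compounds alone.

Working notes on the series. Compound 1 `COc1ccc(S(=O)(=O)Nc2cc(Cl)cc(Cl)c2)cc1N1CCNCC1` gives 0.631 nM in an assay on isolated protein for binding affinity to 5-hydroxytryptamine receptor 6 (Homo sapiens); a higher number here means a weaker inhibitor, a lower number a stronger inhibitor. Compound 2 `COc1cc(Cl)c(C)cc1NS(=O)(=O)c1ccc(OC)c(N2CCNCC2)c1` gives 2 nM in this assay. Compound 3 `COc1ccc(S(=O)(=O)Nc2cc(Cl)c(Cl)cc2Cl)cc1N1CCNCC1` gives 5.01 nM in this assay, the highest of the three numbers, with compound 2 nearest and compound 1 furthest.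

Compound 4 `COc1ccc(S(=O)(=O)Nc2cc(Br)cc(Cl)c2Br)cc1N1CCNCC1` is not yet measured. It differs from compound 3 by 2,5-dibromo-3-chlorophenyl in place of 2,4,5-trichlorophenyl on a sulfonamide nitrogen. Among the compounds with values here, the one step that bears on this position is a 7.9-fold higher number from compound 1 to compound 3 (0.90 log units; beyond the scatter), which changed the halogen pattern on the same ring. Compound 4 keeps the three-halogen count of compound 3 while shifting the pattern, so a step of comparable or smaller size in either direction cannot be excluded, and no step beyond the scatter is firmly expected. Compound 4 is therefore estimated at 4 nM in this assay, in the range 1.5 nM to 12 nM, which means an expected step of a 1.3-fold lower number from compound 3 to compound 4 (0.10 log units; within the scatter).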

Compound 4, inhibition constant: 3.98 nM
Estimate against measurement, compound 4: 1.0-fold (0.00 log units) above; low and high end bracket the measured number.
By their numbers in this assay, from the lowest: compound 1; then compounds 2, 4 and 3 (each within the scatter of the next, the first and the last beyond it).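

In this assay, 2,5-dibromo-3-chlorophenyl in place of 2,4,5-trichlorophenyl on a sulfonamide nitrogen gives a 1.3-fold lower number from compound 3 to compound 4 (0.10 log units; within the scatter), so this exchange of halogens and their pattern leaves the number within the scatter. Against the 3,5-dichlorophenyl of compound 1, the same group gives a 6.3-fold higher number from compound 1 to compound 4 (0.80 log units; beyond the scatter), so compound 3 and compound 4 both stand beyond the scatter from compound 1. No evidence at hand explains these results.

Which single halogen in the pattern matters remains open. Also open, from the compounds shown here alone, is how this position takes an amine or a carboxylic acid on the ring in place of a halogen.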